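Moving the pyridine nitrogen: compound 3 to compound 4

This account rests on a few compounds, and the source may have more. Where it says the series, first, only, none or still open, it means among the compounds named here.

Measured in an assay on CHO-K1 cells for binding affinity to muscarinic acetylcholine receptor M5 (Homo sapiens); a higher number here means a weaker inhibitor, a lower number a stronger inhibitor:
compound 1 `CC(C1=C(CCN(C)C)Cc2ccc(F)cc21)c1ccccn1`: 1050 nM
compound 2 `CN(C)CCC1=C(Cc2ccccn2)c2ccccc2C1`: 3630 nM
compound 3 `CN(C)CCC1=C(Cc2ccncc2)c2ccccc2C1`: 10200 nM

Compound 3 gives the highest number of the three; compound 2 is nearest and compound 1 furthest, both gaps beyond the scatter. Compound 4 `CN(C)CCC1=C(Cc2cccnc2)c2ccccc2C1` is not yet measured. The change from compound 3 is pyridin-3-yl in place of pyridin-4-yl on a saturated chain carbon bound to a double-bonded ring carbon. Within the data shown here, the only measured step at this site is a 2.8-fold higher number from compound 2 to compound 3 (0.45 log units; beyond the scatter), which exchanged pyridin-2-yl for pyridin-4-yl. Among the measured compounds shown here, compound 4 carries the remaining isomer, which no measured compound has, so compound 2 and compound 3 are the only bounds. On that basis a modest fall in the number is expected for compound 4, a 1.7-fold lower number from compound 3 to compound 4 (0.23 log units; within the scatter), possibly not beyond the scatter. Compound 4 is estimated at 6000 nM, range 2500 nM to 15000 nM.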

Compound 4, inhibition constant: 7940 nM
Estimate against measurement, compound 4: 1.3-fold (0.12 log units) below; measured number inside the range.
By their numbers in this assay, from the lowest: compound 1; then compound 2; then compounds 4 and 3 (each within the scatter of the next).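

In this assay the exchange of pyridin-4-yl for pyridin-3-yl gives a 1.3-fold lower number from compound 3 to compound 4 (0.11 log units; within the scatter) and so does not separate these two isomers. Pyridin-2-yl alone stands apart, as the exchange for pyridin-3-yl gives a 2.2-fold higher number from compound 2 to compound 4 (0.34 log units; beyond the scatter) in the same direction as the earlier step to pyridin-4-yl. No evidence in hand explains this difference among the isomers.

Open, on these data alone, is how a plain phenyl or a pyrimidin-2-yl on the same saturated chain carbon would compare with pyridin-2-yl.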